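Lactone versus lactam: a methoxy step repeated

This account rests on a few compounds, and the source may have more. Where it says the series, first, only, none or still open, it means among the compounds named here.

Compound 1 `COc1cc(/C=C/C2CC=CC(=O)O2)cc(OC)c1` gives 9 uM in a functional assay on NCI-H460 cells (Homo sapiens) for inhibition, read by sulforhodamine B assay, with a stated time of 48 h; on this read-out lower numbers stand for stronger inhibition of growth and higher numbers for weaker inhibition of growth. Compound 2 `COc1cc(/C=C/C2CC=CC(=O)O2)cc(OC)c1OC` carries the change methoxy in place of hydrogen on an aromatic carbon and in this assay compound 2 gives 28.8 uM, so the step is a 3.2-fold higher number from compound 1 to compound 2 (0.51 log units; beyond the scatter). Compound 3 `COc1cc(/C=C/C2CC=CC(=O)N2)cc(OC)c1` has a different core; the difference between the core of compound 3 and that of compound 1 is not broken down here. In this assay compound 3 gives 146 uM, the highest number of the three measured. Compound 4 `COc1cc(/C=C/C2CC=CC(=O)N2)cc(OC)c1OC` is not yet measured; it differs from compound 3 by methoxy in place of hydrogen on an aromatic carbon, the same change as from compound 1 to compound 2, at a place described in the same words. Beside that earlier step, the expected step is a 3.1-fold higher number from compound 3 to compound 4 (0.49 log units; beyond the scatter), which rests on compound 1 and compound 2 because a 3.2-fold higher number from compound 1 to compound 2 (0.51 log units; beyond the scatter) was modest yet beyond the scatter. For compound 4 the estimate in this assay is 450 uM, with a real chance that only a limit is reported.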

Compound 4, concentration for growth inhibition (reported as GI): > 864 uM
Compound 4: a limit, no number; the forecaster's own chance of this, stated with the estimate: 40%; at least 1.9-fold (0.28 log units) between middle value and limit.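

Compound 4 gives > 864 uM in this assay, which is a limit and not a number. Methoxy in place of hydrogen on an aromatic carbon thus moves the number in the same direction on the second core, with an at least 5.9-fold higher number from compound 3 to compound 4 (0.77 log units; beyond the scatter), and the change of core with this methoxy present gives an at least 30-fold higher number from compound 2 to compound 4 (1.47 log units; beyond the scatter). The direction carries over, but the size on the core of compound 3 stays unfixed, and no larger effect on that core can be claimed: the same change on two cores in this assay, a 3.2-fold higher number (0.51 log units; beyond the scatter) from compound 1 to compound 2 and an at least 5.9-fold higher number (0.77 log units; beyond the scatter) from compound 3 to compound 4; the limit leaves it open whether they differ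

Still open, going by these compounds, is how the core of compound 3 responds to an amine, a hydroxy or a fluorine at that aromatic carbon. Also open, on these data alone, is whether a longer chain in place of the double-bonded chain keeps the same order between the two cores.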